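The source may report more compounds than this note shows. Statements on the series, on what has been measured and on what is new or still open speak of the compounds shown alone.

The study compares a set of compounds sharing one core. Compound 1 `Cc1c(C(=O)Nc2c(F)cc(-c3cccc(F)c3)cc2F)nc2ccc(F)cc2c1O` and compound 2 `Cc1c(C(=O)Nc2c(F)cc(-c3cccc(F)c3)cc2F)nc2ccc(OC(F)(F)F)cc2c1O` have been measured in a functional assay on Hep 3B2 cells (Homo sapiens) for antiproliferative activity, read by MTT assay, with a stated time of 24 h, tested at 0.05 ug/mL; a higher number here means a stronger effect of the compound at the concentration tested, a lower number a weaker effect. In this assay compound 1 gives 1.25%, and compound 2 gives 1.05%. Among the measured compounds shown here, the one step observed among the measured compounds, a number 0.2 percentage points lower from compound 1 to compound 2 (within the scatter), changes nothing beyond the scatter. Compound 2 thus stands at the lower of the two numbers, with compound 1 nearest, but the two values cannot be told apart.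

Compound 3 `Cc1c(C(=O)Nc2c(F)cc(-c3cccc(F)c3)cc2F)nc2ccc(C(F)(F)F)cc2c1O` is the next compound. It differs from compound 2 in one place: trifluoromethyl in place of trifluoromethoxy on an aromatic carbon. For the measured compounds named here, the only measured step bears on this change just loosely, since it concerns a different exchange at the same aromatic carbon; that step, a number 0.2 percentage points lower from compound 1 to compound 2 (within the scatter), stayed within the scatter. Given that both measured compounds sit near zero in this assay, the account expects no step beyond the scatter for compound 3, so a number 0.2 percentage points higher from compound 2 to compound 3 (within the scatter) is the expected change. Compound 3 is therefore estimated at 1.2%, within a range from -7% to 10%.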

Compound 3, a percentage reported as inhibition, at one concentration (the size of the read-out at that concentration, not a potency): 1.35%
Estimate against measurement, compound 3: 0.2 percentage points below; measured number inside the range.
By their numbers in this assay, from the lowest: compounds 2, 1 and 3 (each within the scatter of the next).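

In this assay, the same aromatic carbon of the shared core has now carried fluoro, trifluoromethoxy and trifluoromethyl, and the three compounds cannot be told apart. Trifluoromethyl in place of trifluoromethoxy gives a number that stands as follows (a number 0.3 percentage points higher from compound 2 to compound 3 (within the scatter)), and trifluoromethyl in place of fluoro gives a second step that also stays within the scatter (a number 0.1 percentage points higher from compound 1 to compound 3 (within the scatter)), so that at this position the exchange of any one of these three groups for another has not moved the read-out beyond the scatter at the single concentration tested. Nothing available here accounts for this flat result.

All three numbers lie near zero, so these compounds leave open whether this position can influence the read-out at all, or whether the three groups would separate under conditions that give a larger effect. Also open, on these data alone, is whether an amine, a carboxylic acid or a longer alkoxy chain on this aromatic carbon would give a number beyond the scatter of those seen with fluoro, trifluoromethoxy and trifluoromethyl.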